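The compounds below may be only part of what the source reports. "The series", "measured", "known", "first", "only" and "open" are said of these compounds alone.

Of the compounds shown here, two have been measured in an assay on HEK293 cells for agonist activity at transient receptor potential cation channel subfamily M member 8 (Homo sapiens), read by fluorescence and calcium flux, with a stated time of 15 min; a higher number here means that more compound is needed for the effect, a lower number that less compound is needed. Compound 1 `CCN(Cc1ccc(C)s1)C(=O)COc1ccc(C)cc1` gives 178 nM. Compound 2 `Cc1ccc(OCC(=O)N(CCCO)Cc2cccs2)cc1` gives 3000 nM, the higher of the two numbers, so more of compound 2 is needed for the effect than of compound 1, and the gap is beyond the scatter. Compound 3 `Cc1ccc(OCC(=O)N(Cc2cccs2)c2cccnc2)cc1` has not been measured yet. It differs from compound 2 in one place: pyridin-3-yl in place of 3-hydroxypropyl on an amide-type nitrogen. Going by the values given here, no step between two measured compounds shows what such a change does, so the expectation rests on the two values alone. A modest drop in the number is expected, a step of a 2.5-fold lower number from compound 2 to compound 3 (0.40 log units; beyond the scatter). For compound 3 the estimate in this assay is 1200 nM, within a range from 300 nM to 5000 nM.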

Compound 3, half-maximal effective concentration: 198 nM
Beside the measured number, compound 3's estimate is 6.1-fold (0.78 log units) above it, and the stated range ends above it.
By their numbers in this assay, from the lowest: compounds 1 and 3 (each within the scatter of the next); then compound 2.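

In this assay, pyridin-3-yl in place of 3-hydroxypropyl on the amide-type nitrogen gives a 15-fold lower number from compound 2 to compound 3 (1.18 log units; beyond the scatter), so what sits at this position can change the number considerably, and a six-membered aromatic ring is accepted there. The change replaces a chain carrying a hydrogen-bond donor with a ring that has none, and this single step cannot separate those two differences. No measurement shown gives a reason for the step.

As far as these compounds go, it remains open whether a plain phenyl ring would do the same as pyridin-3-yl, which would test the ring nitrogen. A propyl chain without the hydroxyl would likewise test whether the hydroxyl or the chain itself goes with the higher number of compound 2.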